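The compounds below may be only part of what the source reports. "The series", "measured", "known", "first", "only" and "open" are said of these compounds alone.

Measured compounds:
compound 1 `O=C1CSC(c2ccc(F)cc2)N1CCN1CCCCC1` — 14%
compound 2 `COc1cccc(C2SCC(=O)N2CCN2CCCCC2)c1` — 11%

Of the compounds shown here, two have been measured in an ADME assay on Vero cells (Chlorocebus sabaeus) for cytotoxicity, read by neutral red uptake, tested at 1575 ug/mL; on this read-out lower numbers stand for a stronger effect and higher numbers for a weaker effect at the one concentration tested. Compound 1 gives 14%, and compound 2 gives 11%. The two numbers lie within the usual scatter of each other, so nothing separates compound 1 from compound 2 on this assay. Among the measured compounds shown here, no step between the two measured compounds is computed here.

Compound 3 `Cc1ccc(C2SCC(=O)N2CCN2CCCCC2)cc1` has not yet been measured in this assay. It differs from compound 1 in one place: methyl in place of fluoro on an aromatic carbon. For the measured compounds named here, nothing among the measured compounds shows what a change of this kind does to the neutral red read-out, so the step expected from compound 1 to compound 3 is no change at the digits printed from compound 1 to compound 3 (within the scatter), in neither direction beyond the scatter. Compound 3 is therefore estimated to give 14% in this assay, in a range from 4% to 28%.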

Compound 3, a percentage reported as activity, at one concentration (the size of the read-out at that concentration, not a potency): 13%
The estimate for compound 3 lay 1 percentage points above the measured number, within the range that was stated.
By their numbers in this assay, from the lowest: compounds 2, 3 and 1 (each within the scatter of the next).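

In this assay the replacement of fluoro by methyl on an aromatic carbon gives a step of a number 1 percentage points lower from compound 1 to compound 3 (within the scatter) and is the first single-place change shown in this series. At this position, para to a large group, the 4-fluorophenyl and 4-methylphenyl forms therefore cannot be told apart on this read-out. Nothing measured bears on why the two compounds read alike.

The compounds shown leave open whether a different group at this same place, such as an amine, a carboxylic acid or a longer chain, would shift the read-out beyond the scatter. They also leave open whether a single change elsewhere on the shared core would do so.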